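Nitro for Bromo on the Hydrazone Aryl Ring

The compounds below may be only part of what the source reports. "The series", "measured", "known", "first", "only" and "open" are said of these compounds alone.

Measured compounds:
compound 1 `Cc1c(C(=O)N/N=C/c2ccc(C(=O)O)cc2)no[n+]1[O-]`: > 300000 nM
compound 2 `Cc1c(C(=O)N/N=C/c2ccc(Br)cc2)no[n+]1[O-]`: 162000 nM

In an ADME assay on J774.1 cells (Mus musculus) for cytotoxicity, read by MTT assay, with a stated time of 48 h (on this read-out lower numbers stand for stronger inhibition and higher numbers for weaker inhibition), compound 2 gives 162000 nM, the only plain number shown. For compound 1 the reading > 300000 nM is a limit of the assay (the limit of > 300000 nM in this assay, at which 1 of the 2 values shown sits). Among the measured compounds shown here, the single measured step, an at least 1.8-fold lower number from compound 1 to compound 2 (0.26 log units; that floor lies within the scatter), is all that bears on the next change. Compound 3 `Cc1c(C(=O)N/N=C/c2ccc([N+](=O)[O-])cc2)no[n+]1[O-]` differs from compound 2 by nitro in place of bromo on an aromatic carbon. For the measured compounds named here, no measured step swaps bromo for nitro, and the one step available stays within the scatter, so no step beyond the scatter is expected, a 1.0-fold lower number from compound 2 to compound 3 (0.01 log units; within the scatter). Compound 3 is therefore estimated at 160000 nM, between 60000 nM and 400000 nM.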

Compound 3, half-maximal inhibitory concentration: > 300000 nM
Compound 3 ended at the assay's limit; the forecaster's own chance of this, stated with the estimate: 30%; at least 1.8-fold (0.27 log units) between middle value and limit.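

With nitro in place of bromo on the aromatic carbon para to a large group, the change gives an at least 1.8-fold higher number from compound 2 to compound 3 (0.26 log units; that floor lies within the scatter). In this assay compound 3 gives > 300000 nM, which is a limit of the assay and not a number. Compound 1 and compound 3 now rest at the same limit, so the step between them cannot be read: the limit of > 300000 nM in this assay, at which 2 of the 3 values shown sit.

From the compounds shown here alone, compound 2 alone carries a plain number, so how far nitro or carboxy truly lies from bromo stays open. Also open, going by these compounds, is whether an amine or a methoxy group here would give a plain number.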